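The source may report more compounds than this note shows. Statements on the series, on what has been measured and on what is new or still open speak of the compounds shown alone.

Compound 1 `CCCOc1cccc(-c2[nH]c3cc(OC)ccc3c(=O)c2C(=O)OCC)c1` — in an ADME assay on BJ cells (Homo sapiens) for cytotoxicity, read by luminescence, with a stated time of 72 h (a lower number here means that less compound is needed, a higher number that more compound is needed for the effect), compound 1 gives > 21500 nM, which is a limit of the assay and not a number.
Compound 2 `CCOC(=O)c1c(-c2cccc(OC(C)C)c2)[nH]c2cc(OC)ccc2c1=O` — in this assay compound 2 gives > 21500 nM, again a limit.
Compound 3 `CCOC(=O)c1c(-c2cccc(Cl)c2)[nH]c2cc(OC)ccc2c1=O` — in this assay compound 3 gives > 21500 nM, also a limit.

Compound 1 therefore stands only at the limit of > 21500 nM in this assay, at which 3 of the 3 values shown sit, in this assay; no number is known for it. The change to compound 4 `CCOC(=O)c1c(-c2cccc(CO)c2)[nH]c2cc(OC)ccc2c1=O` is hydroxymethyl in place of propoxy on an aromatic carbon. Going by the values given here, the steps that bear on it, from compound 1 to compound 2 a step that the two limits leave unreadable from compound 1 to compound 2, from compound 1 to compound 3 a step that the two limits leave unreadable from compound 1 to compound 3 and from compound 2 to compound 3 a step that the two limits leave unreadable from compound 2 to compound 3, are all unreadable, so no direction or size can be drawn from them. The account expects no readable step in this assay, a step that the limit leaves unreadable from compound 1 to compound 4, and estimates compound 4 at 25000 nM, between 10000 nM and 100000 nM, most likely reported once more as a limit.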

Compound 4, half-maximal effective concentration: > 21500 nM
Compound 4 gave a limit, no number (the forecaster's own chance of this, stated with the estimate: 85%); the middle value does not contradict the limit.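

Going by these compounds alone, with compound 4 again at a limit and not a number, no step between it and compound 1, compound 2 or compound 3 can be read in this assay: the limit of > 21500 nM in this assay, at which 4 of the 4 values shown sit. The compounds shown leave open what concentration any of them needs for the effect, and whether propoxy, isopropoxy, chloro and hydroxymethyl differ at all.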